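Trifluoromethyl in place of fluoro in compound 1

The compounds below may be only part of what the source reports. "The series", "measured", "known", "first", "only" and "open" are said of these compounds alone.

Compound 1 `Oc1cccc(-c2cc(-c3ccc(F)cc3)cc(-c3ccccc3O)n2)c1`: > 50000 nM (a limit)
Compound 2 `Oc1ccc(-c2cc(-c3ccc(F)cc3)cc(-c3cccc(O)c3)n2)cc1`: 8080 nM (a number)

In a functional assay on HeLa cells (Homo sapiens) for inhibition (on this read-out lower numbers stand for stronger inhibition and higher numbers for weaker inhibition), compound 1 gives > 50000 nM as a limit of the assay and not a number. Compound 3 `Oc1cccc(-c2cc(-c3ccc(C(F)(F)F)cc3)cc(-c3ccccc3O)n2)c1` carries trifluoromethyl in place of fluoro on an aromatic carbon of the core of compound 1. For the measured compounds named here, the one measured step, an at least 6.1-fold lower number from compound 1 to compound 2 (0.79 log units; beyond the scatter), lies at another place, so no measured step bears on this change. No step beyond the scatter is therefore expected in this assay, and the estimated step is a number no higher from compound 1 to compound 3 (the limit leaves the size open) here. Compound 3 is expected at 50000 nM (estimated range 20000 nM to 100000 nM).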

Compound 3, half-maximal inhibitory concentration: > 50000 nM
Compound 3 ended at the assay's limit; the forecaster's own chance of this, stated with the estimate: 65%; the middle value lies on the limit itself.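

For the compounds shown here, compound 1 and compound 3 both end at a limit of this assay and not at a number, so no step between them can be read: the limit of > 50000 nM in this assay, at which 2 of the 3 values shown sit. Going by these compounds, whether trifluoromethyl in place of fluoro changes inhibition on this core remains open.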